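Halogen exchange in a three-compound series: outlook for compound 4

A few compounds are considered here, and "the series" means these few. Any claim that something is new, unique, unknown or untested is made for them only; others in the source may bear on it.

Measured so far in a functional assay on NCI-H292 cells (Homo sapiens) for cytotoxicity, read by MTT assay, with a stated time of 72 h, tested at 10 ug/mL; on this read-out lower numbers stand for less inhibition of growth and higher numbers for more inhibition of growth at the one concentration tested:
compound 1 `O=C1NC(=S)/C(=C/c2ccccc2Br)S1` gives 36.9%
compound 2 `O=C1NC(=S)/C(=C/c2cccc(Cl)c2)S1` gives 30.9%
compound 3 `O=C1NC(=S)/C(=C/c2cccc(F)c2)S1` gives 26.8%

Compound 1 carries the highest of the three numbers. Its gap to compound 2 lies within the scatter, so the two cannot be ranked; its gap to compound 3 lies beyond the scatter, so compound 1 and compound 3 are separated. Among the compounds with values here, only one single-point step exists among the measured compounds: a number 4.1 percentage points lower from compound 2 to compound 3 (within the scatter). Within the data shown here, that step is the only halogen exchange on record here.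

Compound 4 `O=C1NC(=S)/C(=C/c2ccccc2F)S1` differs from compound 1 by fluoro in place of bromo on an aromatic carbon. Among the measured compounds shown here, the step from compound 2 to compound 3 bears on it as the nearest precedent, a chloro-to-fluoro exchange that stayed within the scatter. For the measured compounds named here, no measured step replaces bromo by fluoro, and no measured step alters the ring at the place where compound 1 carries its bromo, so the precedent is indirect. The expectation is a step of similar or slightly larger size in the same downward direction, likely within or at the edge of the scatter: a number 6.9 percentage points lower from compound 1 to compound 4 (within the scatter). Compound 4 is therefore estimated at 30% in this assay, with a range from 20% to 40%.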

Compound 4, percent growth inhibition at one concentration: 40.4%
Estimate against measurement, compound 4: 10.4 percentage points below; measured number outside the range, above it.
By their numbers in this assay, from the lowest: compounds 3, 2, 1 and 4 (each within the scatter of the next, the first and the last beyond it).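

On the aromatic carbon ortho to a group of 8 heavy atoms, fluoro in place of bromo gives a number 3.5 percentage points higher from compound 1 to compound 4 (within the scatter) in this assay, so bromo and fluoro cannot be told apart at this place on this read-out. This is the first step on record at this place, and it stands alongside a number 4.1 percentage points lower from compound 2 to compound 3 (within the scatter), a fluoro-for-chloro exchange elsewhere on the ring; both halogen exchanges stay within the scatter, no step shown goes against that, and the claim reaches only these two pairs. No measurement shown bears on why the exchange at this place leaves the number within the scatter.

Still open is whether any group at this place can move the number beyond the scatter, as the compounds shown carry only bromo and fluoro there, and an amine, a carboxylic acid, a methoxy group or a longer carbon chain would test this beyond the halogens. Also open is how the step from bromo to fluoro behaves at other concentrations in this assay, as the compounds shown are each read at a single concentration.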